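A few compounds are considered here, and "the series" means these few. Any claim that something is new, unique, unknown or untested is made for them only; others in the source may bear on it.

Measured compounds:
Compound 1, `Cc1ccc(Oc2ccc3nc(COc4cccc(C(=O)O)c4)n(C)c3n2)cc1`, gives 1.7 in a physicochemical assay for lipophilicity, read by LC-MS, in phosphate buffer, measured as octanol-water partition, with a stated time of 30 min, at pH 7.4, tested at 200 mM; a lower number here means a more polar compound, a higher number a more lipophilic compound.
Compound 2, `Cc1ccc(Oc2ccc3nc(COc4cccc(C(=O)O)c4)n(C)c3n2)c(C)c1`, gives 2.3 in this assay.
Compound 3, `Cn1c(COc2cccc(C(=O)O)c2)nc2ccc(Oc3ncccc3Cl)cc21`, gives 1.1 in this assay.

Among these three, compound 3 stands lowest in this assay: compound 1 sits higher by an amount beyond the scatter, and compound 2 higher still. Within the data shown here, the one step between compounds that differ in a single place is a number 0.60 log units higher from compound 1 to compound 2 (beyond the scatter), a modest rise that came with a methyl in place of hydrogen on an aromatic carbon.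

Compound 4, `Cc1cc(F)cnc1Oc1ccc2nc(COc3cccc(C(=O)O)c3)n(C)c2c1`, has not yet been measured. It differs from compound 3 in one place: 5-fluoro-3-methylpyridin-2-yl in place of 3-chloropyridin-2-yl on an oxygen on an aromatic ring. Here a chlorine is exchanged for a methyl, and a fluorine enters as well. Among the measured compounds shown here, the step from compound 1 to compound 2 is the only measured guide, and it bears only in part: there a methyl replaced a hydrogen while nothing left. For the measured compounds named here, no measured pair shows a chlorine swapped for a methyl, nor a fluorine added. A small rise in this assay is expected, one that may stay within the scatter, and the step is estimated at a number 0.20 log units higher from compound 3 to compound 4 (within the scatter). Compound 4 is expected to read 1.3, within a range from 0.9 to 1.7.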

Compound 4, distribution coefficient: 1.1
Compound 4: the middle estimate sits 0.20 log units above what was measured; measured number inside the range.
By their numbers in this assay, from the lowest: compounds 3 and 4 (each within the scatter of the next); then compound 1; then compound 2.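

In this assay, replacing 3-chloropyridin-2-yl with 5-fluoro-3-methylpyridin-2-yl on an oxygen on an aromatic ring gives no change at the digits printed from compound 3 to compound 4 (within the scatter). Among these compounds, this is the first look at a change in which one substituent leaves the pyridine ring and two enter, and it shows that such a double exchange at this place can leave the reading within the scatter, even though the entering group is one heavy atom larger. The earlier compounds offered only a single methyl taking the place of a hydrogen on an aromatic carbon, a simpler change that gave a number 0.60 log units higher from compound 1 to compound 2 (beyond the scatter) on a different ring, and nothing shown here explains why the new exchange leaves the reading where it is.

On these data alone, because the methyl and the fluorine enter together, their separate contributions stay unknown, and a matching reading could come either from two small effects that offset each other or from two that are each negligible. Still open, as far as these compounds go, is how this assay would read for 3-methylpyridin-2-yl without the fluorine, for 5-fluoropyridin-2-yl without the methyl, or for a ring carrying an amine or a methoxy group at the same place.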